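Adding a Second Chloro to an Anilino Ring

A few compounds are considered here, and "the series" means these few. Any claim that something is new, unique, unknown or untested is made for them only; others in the source may bear on it.

Measured compounds:
compound 1 `O=C(CSc1nc(Nc2ccccc2)c2ccccc2n1)Nc1cccc([N+](=O)[O-])c1`, 11800 nM
compound 2 `C=CC(=O)Nc1cccc(NC(=O)CSc2nc(Nc3ccccc3Cl)c3ccccc3n2)c1`, 14400 nM

Both were tested in a functional assay on PC-3 cells (Homo sapiens) for inhibition, read by MTT assay, with a stated time of 72 h; on this read-out higher numbers stand for weaker inhibition and lower numbers for stronger inhibition. Compound 2 gives the higher of the two numbers, but its gap to compound 1 lies within the scatter, so the two show no real difference. Compound 3 `C=CC(=O)Nc1cccc(NC(=O)CSc2nc(Nc3ccc(Cl)cc3Cl)c3ccccc3n2)c1` is not yet measured. It differs from compound 2 by one change: chloro in place of hydrogen on an aromatic carbon. For the measured compounds named here, no measured pair shows this kind of change, so the step of a 1.2-fold lower number from compound 2 to compound 3 (0.08 log units; within the scatter) is expected to be small, no more than the scatter. Compound 3 is therefore expected to give about 12000 nM, within 5000 nM to 30000 nM.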

Compound 3, half-maximal inhibitory concentration: 25700 nM
The estimate for compound 3 lay 2.1-fold (0.33 log units) below the measured number; the measured number falls inside the stated range.
By their numbers in this assay, from the lowest: compounds 1, 2 and 3 (each within the scatter of the next, the first and the last beyond it).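

In this assay, for the compounds shown here, chloro in place of hydrogen, para to a large group and meta to a chloro group, gives a 1.8-fold higher number from compound 2 to compound 3 (0.25 log units; within the scatter) and so offers the first measured look at this change. Going from 2-chlorophenyl to 2,4-dichlorophenyl produces no real difference, so this position tolerates a chloro without a clear gain or loss. Nothing measured here explains the result. Going by these compounds, whether an amine, a methoxy group or a carboxylic acid at this position would also leave the number unchanged remains open.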